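The compounds below may be only part of what the source reports. "The series", "measured", "known", "first", "only" and "open" are said of these compounds alone.

The compounds share one core and differ only in the group attached to a carbonyl carbon next to an amide-type nitrogen. In a functional assay on A498 cells (Homo sapiens) for inhibition, read by sulforhodamine B assay, with a stated time of 48 h, tested at 10 uM (on this read-out higher numbers stand for a weaker effect at the one concentration tested and lower numbers for a stronger effect), compound 1 `COc1cc(Cl)cc(-c2nn(-c3cccc(NC(=O)c4ccc(Cl)c(Cl)c4)c3)cc2-c2ccncc2)c1` gives -0.94%. Compound 2 `COc1cc(Cl)cc(-c2nn(-c3cccc(NC(=O)Nc4cccc(C(F)(F)F)c4)c3)cc2-c2ccncc2)c1` in this assay gives -6.74%; on the numbers shown, compound 2 and compound 1 stand within the scatter of each other, so the two cannot be told apart. Within the data shown here, the one measured step, a number 5.8 percentage points lower from compound 1 to compound 2 (within the scatter), shows that swapping the group on the carbonyl carbon left the read-out essentially unchanged.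

Compound 3 `COc1cc(Cl)cc(-c2nn(-c3cccc(NC(=O)c4cccc(C(F)(F)F)c4)c3)cc2-c2ccncc2)c1` is not yet measured. It differs from compound 2 in this way: 3-(trifluoromethyl)phenyl in place of (3-(trifluoromethyl)phenyl)amino on a carbonyl carbon. Among the measured compounds shown here, no measured step mirrors this exact change; the only step available is the one from compound 1 to compound 2, which is within the scatter. For the measured compounds named here, compound 3 is therefore expected to show a step of a number 3.7 percentage points higher from compound 2 to compound 3 (within the scatter) in this assay, that is, nothing beyond the scatter, because the one step that bears on it, a number 5.8 percentage points lower from compound 1 to compound 2 (within the scatter), was itself within the scatter. For compound 3 in this assay the estimated value is -3%, within a range from -15% to 12%.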

Compound 3, a percentage reported as activity, at one concentration (the size of the read-out at that concentration, not a potency): 21.2%
Compound 3: the middle estimate sits 24.2 percentage points below what was measured, outside the stated range (above it).
By their numbers in this assay, from the lowest: compounds 2 and 1 (each within the scatter of the next); then compound 3.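

In this assay, the group on the carbonyl carbon proves able to move the read-out: putting 3-(trifluoromethyl)phenyl in place of (3-(trifluoromethyl)phenyl)amino gives a number 27.9 percentage points higher from compound 2 to compound 3 (beyond the scatter), which means a weaker effect at the one concentration tested. The aryl group matters as well, since keeping the direct link to the carbonyl carbon and putting 3-(trifluoromethyl)phenyl in place of 3,4-dichlorophenyl gives a number 22.1 percentage points higher from compound 1 to compound 3 (beyond the scatter). Compounds 1 and 2 differ in both the amino nitrogen and the substituents on the aromatic ring, so their closeness did not show that either feature was unimportant: each of the two changes, made alone, separates compound 3 from its neighbour, while together they leave compounds 1 and 2 within the scatter of each other.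

The compounds shown leave open how the read-out would respond to a morpholine, a piperidine or a short alkyl chain on the carbonyl carbon, where no aromatic ring is present. Nothing given here accounts for why these changes have the effects seen.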